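A few compounds are considered here, and "the series" means these few. Any claim that something is new, unique, unknown or untested is made for them only; others in the source may bear on it.

Of the compounds shown here, three built on a shared core have been tested in a functional assay on MDA-MB-435 cells (Homo sapiens) for cytotoxicity, read by MTT assay, with a stated time of 72 h; on this read-out lower numbers stand for stronger inhibition and higher numbers for weaker inhibition. Compound 1 `N[C@H]1CC[C@H](Nc2c(C(=O)NCc3ccc(F)cc3)nc(N3CCCCS3(=O)=O)c3cccnc23)CC1` gives 5000 nM, and compound 3 `NCCNc1c(C(=O)NCc2ccc(F)cc2)nc(Br)c2cccnc12` gives 12000 nM. Going by the values given here, these are the only two exact numbers available.

Compound 2 `O=C(NCc1ccc(F)cc1)c1nc(NCCO)c2cccnc2c1O` has no exact number, only a limit of the assay: > 20000 nM. Compound 2 therefore stands at the limit of > 20000 nM in this assay, at which 1 of the 3 values shown sits.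

The next compound to be tested is compound 4 `O=CNCCCCCCNc1nc(C(=O)NCc2ccc(F)cc2)c(O)c2ncccc12`, which keeps the core of compound 2 and changes its side chain. The difference is 4-(formylamino)butyl in place of hydroxy on a saturated chain carbon, two bonds along the chain from a nitrogen on an aromatic ring. In other words, the short (2-hydroxyethyl)amino group becomes (6-(formylamino)hexyl)amino, and the end of the chain now carries a formylamino group rather than a hydroxy group.

Among the compounds with values here, no measured pair in this small set shows what such a change does, so any forecast is loose. Within the data shown here, the only guide is that compound 3, at 12000 nM, and compound 1, at 5000 nM, both gave numbers within the range of the assay. The expected change, an at least 1.3-fold lower number from compound 2 to compound 4 (0.12 log units; that floor lies within the scatter), is therefore a modest one towards stronger inhibition, and it may prove hard to distinguish from no change at all. The assay could again report only a limit.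

For compound 4, the estimated value is 15000 nM, with an expected range of 5000 nM to 30000 nM.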

Compound 4, half-maximal inhibitory concentration: 16000 nM
Beside the measured number, compound 4's estimate is 1.1-fold (0.03 log units) below it; the measured number falls inside the stated range.
By their numbers in this assay, from the lowest: compound 1; then compounds 3 and 4 (each within the scatter of the next). At a limit, above all of these: compound 2.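

In this assay, going by these compounds alone, putting 4-(formylamino)butyl in place of hydroxy on a saturated chain carbon, two bonds along the chain from a nitrogen on an aromatic ring, gives the first step in this set that can be read: an at least 1.2-fold lower number from compound 2 to compound 4 (0.09 log units; that floor lies within the scatter). This shows that the side chain at this position can be made much longer and end in a formylamino group while compound 4 still gives an exact number in the range of the assay, but the step does not establish a real gain in inhibition. The true size of the step is unknown, as the value for compound 2 is a limit of the assay and not a number: the limit of > 20000 nM in this assay, at which 1 of the 4 values shown sits.

The single step changes the length of the chain and the group at its end together, and the compounds shown do not separate these two changes. From the compounds shown here alone, it remains open how this assay would read for the same long chain ending in an amine or a carboxylic acid, or for a shorter chain ending in formylamino.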